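Acylating the amine of compound 2: solubility notes

This account rests on a few compounds, and the source may have more. Where it says the series, first, only, none or still open, it means among the compounds named here.

Values so far in a physicochemical assay for solubility, measured as kinetic solubility, with a stated time of 1 h, at pH 7.4; on this read-out lower numbers stand for lower solubility and higher numbers for higher solubility:
- compound 1 `N#CCC(=O)Nc1nc(-c2ccc(Cl)c(Cl)c2)c[nH]1`: 14000 nM
- compound 2 `NC1=NN(c2ccc(Cl)c(Cl)c2)CC1`: 69000 nM

Compound 2 has the higher of the two numbers at 69000 nM, and compound 1 lies lower, with the gap beyond the usual scatter of repeated measurements. Compound 3 `N#CCC(=O)NC1=NN(c2ccc(Cl)c(Cl)c2)CC1` has not yet been measured. It has (cyanomethyl)carbonyl in place of hydrogen on an amine nitrogen of compound 2: (cyanomethyl)carbonyl in place of hydrogen on an amine nitrogen. The same difference reads as amino to ((cyanomethyl)carbonyl)amino.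

For the measured compounds named here, no pair of measured compounds differs in one place only, so the size of this step in this assay has no direct precedent. Going by the values given here, the only guide is compound 1 at 14000 nM, which carries the same ((cyanomethyl)carbonyl)amino group on its own core. On that thin basis, a downward move beyond the scatter is expected, and the expected size is a 3.1-fold lower number from compound 2 to compound 3 (0.50 log units; beyond the scatter). The range is kept wide. For compound 3 the estimated value is 22000 nM, with an expected range of 7000 nM to 60000 nM.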

Compound 3, solubility: 202000 nM
The estimate for compound 3 lay 9.2-fold (0.96 log units) below the measured number; measured number above the stated range.
By their numbers in this assay, from the lowest: compound 1; then compound 2; then compound 3.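

In this assay, for the compounds shown here, (cyanomethyl)carbonyl in place of hydrogen on the amine nitrogen gives a 2.9-fold higher number from compound 2 to compound 3 (0.47 log units; beyond the scatter), the first step that can be read at a single place. This shows that on this core the amine hydrogen can give way to the acyl group with the number moving up rather than down, and the step lies beyond the usual scatter. No measurement in hand accounts for the rise.

Only this one acyl group is shown at this nitrogen, so it remains open whether the step belongs to the carbonyl, to the nitrile or to the whole group; a plain acetyl group, a longer chain ending in a nitrile, or a carboxylic acid in place of the nitrile would separate these readings. Also open is whether the step carries over to another core, as compound 1 bears the same ((cyanomethyl)carbonyl)amino group but has no partner among the compounds shown that differs from it in that one place.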